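Chloro for fluoro, second occurrence: cytotoxicity notes

A few compounds are considered here, and "the series" means these few. Any claim that something is new, unique, unknown or untested is made for them only; others in the source may bear on it.

Measured in an ADME assay on Huh-7 cells (Homo sapiens) for cytotoxicity, with a stated time of 3 days; a higher number here means that more compound is tolerated, a lower number that less compound is tolerated:
compound 1 `O=C(NC1CC1)c1c(NO)cc(-c2ccc(F)cc2)oc1=O`, a limit of the assay: > 20000 nM
compound 2 `O=C(NC1CC1)c1c(NO)cc(-c2ccc(Cl)cc2)oc1=O`: 12800 nM
compound 3 `O=C(Nc1ccc(F)cc1)c1c(NO)cc(-c2cccs2)oc1=O`, a limit of the assay: > 20000 nM

From compound 1 to compound 2 the change is chloro in place of fluoro on an aromatic carbon, and it gives an at least 1.5-fold lower number from compound 1 to compound 2 (0.19 log units; that floor lies within the scatter). How the core of compound 3 differs from the core of compound 1 is not broken down here. Compound 4 `O=C(Nc1ccc(Cl)cc1)c1c(NO)cc(-c2cccs2)oc1=O` carries the same change against compound 3, namely (chloro in place of fluoro on an aromatic carbon). Compound 3 stands at the limit of > 20000 nM in this assay, at which 2 of the 3 values shown sit, so only a limit is known for it. For compound 4 a step of about an at least 1.3-fold lower number from compound 3 to compound 4 (0.12 log units; that floor lies within the scatter) is expected, because an at least 1.5-fold lower number from compound 1 to compound 2 (0.19 log units; that floor lies within the scatter) lies within the scatter and gives no firm direction. Compound 4 is therefore estimated at 15000 nM, between 7000 nM and 40000 nM, with a real chance that this assay again reports only a limit.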

Compound 4, half-maximal cytotoxic concentration: > 20000 nM
Compound 4 was reported as a limit; the forecaster's own chance of this, stated with the estimate: 45%; middle value at least 1.3-fold (0.12 log units) away from the limit.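

In this assay compound 4 gives > 20000 nM, a limit of the assay. Compound 3 also sits at a limit, so no step between compound 3 and compound 4 can be read: the limit of > 20000 nM in this assay, at which 3 of the 4 values shown sit.

On these data alone, whether chloro in place of fluoro changes the number in this assay for this pair stays open.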